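The compounds below may be only part of what the source reports. "The series", "measured", "known", "first", "only" and "open" are said of these compounds alone.

Compound 1 `COc1ccc(/C=C(/SCc2ccc(Cl)cc2)C(=O)c2ccc(Br)cc2)cc1`, compound 3 `COc1ccc(/C=C(/SCc2ccc(Cl)cc2)C(=O)c2ccc(C(=O)O)cc2)cc1` and compound 2 `O=C(O)c1ccc(C(=O)/C(=C\c2ccc([N+](=O)[O-])c(O)c2)SCc2ccc(Br)cc2)cc1` have been run in a functional assay on DU-145 cells (Homo sapiens) for inhibition, read by trypan blue exclusion, with a stated time of 96 h; on this read-out higher numbers stand for weaker inhibition of growth and lower numbers for stronger inhibition of growth. In this assay compound 1 gives 10000 nM. Compound 3 gives 10000 nM, and compound 2 gives 10000 nM. The change from compound 3 to compound 1, (bromo in place of carboxy on an aromatic carbon), gives no change at the digits printed from compound 3 to compound 1 (within the scatter). How the core of compound 2 differs from the core of compound 3 is not broken down here, but the two values lie level with each other.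

Compound 4 `O=C(/C(=C\c1ccc([N+](=O)[O-])c(O)c1)SCc1ccc(Br)cc1)c1ccc(Br)cc1` is not yet measured. It differs from compound 2 by bromo in place of carboxy on an aromatic carbon, the same change as from compound 3 to compound 1, at the same place. Because no change at the digits printed from compound 3 to compound 1 (within the scatter), the step from compound 2 to compound 4 in this assay is expected to be no change at the digits printed from compound 2 to compound 4 (within the scatter). Compound 4 is therefore estimated at 10000 nM, expected between 3000 nM and 30000 nM.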

Compound 4, concentration for 50% growth inhibition: 10000 nM
For compound 4 middle estimate and measured number coincide at the digits printed; the range from low to high includes it.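

In this assay, bromo in place of carboxy on an aromatic carbon gives no change at the digits printed from compound 2 to compound 4 (within the scatter), and the two cores agree on this change: the same change on two cores in this assay, no change at the digits printed (within the scatter) from compound 3 to compound 1 and no change at the digits printed (within the scatter) from compound 2 to compound 4, 1.0-fold (0.00 log units) apart, within the scatter of two such steps. The swap of 4-carboxyphenyl to 4-bromophenyl therefore reads the same on both cores shown. This agreement rests on a single shared level, with compound 4 at 10000 nM and the other three compounds printing the same value, so it does not show how the change would read on a core with a different value.

On these data alone, it remains open whether an amine or a nitrile at that aromatic carbon would shift the value. As far as these compounds go, it is also open whether any other core would give the same result.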